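The compounds below may be only part of what the source reports. "The series", "measured", "known", "first", "only" and "open" are said of these compounds alone.

Compound 1, with the structure `Cc1ccc(N(C)S(=O)(=O)C2CC3OC2C(c2ccc(NC(=O)CCCCCCC(=O)O)cc2)=C3c2ccc(O)cc2)cc1`, is the starting point. In an ADME assay on Vero cells (Chlorocebus sabaeus) for antiproliferative activity, read by MTT assay, with a stated time of 72 h (a lower number here means a stronger inhibitor, a higher number a weaker inhibitor), compound 1 gives > 100000 nM, which is a limit of the assay rather than a number. Compound 2, with the structure `CN(c1ccccc1Cl)S(=O)(=O)C1CC2OC1C(c1ccc(NC(=O)CCCCCCC(=O)O)cc1)=C2c1ccc(O)cc1`, differs from compound 1 by a 2-chlorophenyl in place of a 4-methylphenyl on a sulfonamide nitrogen. In this assay compound 2 gives > 100000 nM, again only a limit. Compound 3, with the structure `CCN(c1ccccc1)S(=O)(=O)C1CC2OC1C(c1ccc(NC(=O)CCCCCCC(=O)O)cc1)=C2c1ccc(O)cc1`, carries an ethyl(phenyl)amino in place of the methyl(4-methylphenyl)amino on the sulfonyl sulfur. In this assay compound 3 gives > 100000 nM, also a limit. Since (the limit of > 100000 nM in this assay, at which 3 of the 3 values shown sit), the step that the two limits leave unreadable from compound 1 to compound 2 and the step that the two limits leave unreadable from compound 1 to compound 3 cannot be read in size or direction.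

Compound 4, with the structure `CCN(c1cccc(OC)c1)S(=O)(=O)C1CC2OC1C(c1ccc(NC(=O)CCCCCCC(=O)O)cc1)=C2c1ccc(O)cc1`, is not yet measured. Its change from compound 1 is ethyl(3-methoxyphenyl)amino in place of methyl(4-methylphenyl)amino on a sulfonyl sulfur. The nearest measured step is that from compound 1 to compound 3, which was unreadable, so no step beyond the scatter can be predicted. Compound 4 is therefore expected to sit at 200000 nM, within 80000 nM to 1000000 nM, an expected step that the limit leaves unreadable from compound 1 to compound 4.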

Compound 4, half-maximal inhibitory concentration: > 100000 nM
Compound 4 was reported as a limit; the forecaster's own chance of this, stated with the estimate: 85%; the middle value is on the limit's open side.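

Compound 4 also gives only a limit, so its steps from compound 1, compound 2 and compound 3 cannot be read in size or direction: the limit of > 100000 nM in this assay, at which 4 of the 4 values shown sit. The compounds shown leave open whether any change of the group on the sulfonyl sulfur alters activity in this assay.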